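Dropping one methyl from the ester chain of compound 2

The source may report more compounds than this note shows. Statements on the series, on what has been measured and on what is new or still open speak of the compounds shown alone.

Measured in a functional assay on A549 cells (Homo sapiens) for cytotoxicity, read by MTT assay; on this read-out lower numbers stand for stronger inhibition and higher numbers for weaker inhibition:
- compound 1 `COc1ccc(-c2oc3c(CC=C(C)C)c(OCCOC(=O)CCC(=O)O)cc(O)c3c(=O)c2OCCOC(=O)CCC(=O)O)cc1`: > 100000 nM, a limit of the assay
- compound 2 `CCOC(=O)C(C)Oc1cc(O)c2c(=O)c(O)c(-c3ccc(OC)cc3)oc2c1CC=C(C)C`: 26500 nM
- compound 3 `COc1ccc(-c2oc3c(CC=C(C)C)c(OCCCC(=O)O)cc(O)c3c(=O)c2OCCCC(=O)O)cc1`: 26000 nM

Compound 2 and compound 3 lie within the usual scatter of each other. Compound 1 gives only a limit, not a number.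

Compound 4 `CCOC(=O)COc1cc(O)c2c(=O)c(O)c(-c3ccc(OC)cc3)oc2c1CC=C(C)C` differs from compound 2 in one place: hydrogen in place of methyl on a saturated chain carbon bound to a carbonyl carbon and an oxygen on an aromatic ring. Hydrogen stands in place of methyl on a saturated chain carbon bound to a carbonyl carbon and an oxygen on an aromatic ring. For the measured compounds named here, no measured pair shows this change, so no step beyond the scatter is expected in this assay, and the starting point is compound 2 at 26500 nM. The estimated step of a 1.2-fold lower number from compound 2 to compound 4 (0.08 log units; within the scatter) is small. Compound 4 is expected at 22000 nM, within an estimated range of 9000 nM to 55000 nM.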

Compound 4, half-maximal inhibitory concentration: 41600 nM
Compound 4: the middle estimate sits 1.9-fold (0.28 log units) below what was measured; the measured number falls inside the stated range.
By their numbers in this assay, from the lowest: compounds 3, 2 and 4 (each within the scatter of the next). At a limit, above all of these: compound 1.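

For the compounds shown here, the methyl on the saturated chain carbon bound to a carbonyl carbon and an oxygen on an aromatic ring gives the first single-place change that can be read in this assay, and the result is a 1.6-fold higher number from compound 2 to compound 4 (0.20 log units; within the scatter). At this position, hydrogen and methyl cannot be told apart in this assay. Only compound 1 stands at a limit, so this step rests on two real numbers: the limit of > 100000 nM in this assay, at which 1 of the 4 values shown sits.

From the compounds shown here alone, it remains open whether a longer chain or a phenyl group on this carbon would move the number beyond the scatter. Going by these compounds, the effect of a carboxylic acid in place of the ethyl ester also remains open.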